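Swapping the Small Ring in a Pain Test Series

A few compounds are considered here, and "the series" means these few. Any claim that something is new, unique, unknown or untested is made for them only; others in the source may bear on it.

Three measured compounds share a six-membered carbon ring carrying two groups. Compound 1 `Nc1nnc(-c2ccccc2Sc2ccccc2)o1` gives 63.7% in a functional assay on the whole organism (strain NMRI) for inhibition, with Mus musculus as the target, in the formalin test, with a stated time of 30 min, at a dose of 30 umol/kg by the intraperitoneal route; on this read-out lower numbers stand for less inhibition and higher numbers for more inhibition at the one dose given (going by the name of the read-out). Compound 3 `S=c1[nH]nc(-c2ccccc2Sc2ccccc2)[nH]1` reaches 79.6%; the change a group of 6 heavy atoms (2 carbon, 3 nitrogen, 1 sulfur; one five-membered aromatic ring with 3 hetero atoms) in place of a group of 6 heavy atoms (2 carbon, 3 nitrogen, 1 oxygen; one five-membered aromatic ring with 3 hetero atoms), on an aromatic carbon produced the step of a number 15.9 percentage points higher from compound 1 to compound 3 (beyond the scatter). Compound 2 `Nc1nnc(-c2ccccc2S(=O)(=O)c2ccccc2)o1` gives 68.3% in this assay; how its core differs from that of compound 1 is not broken down here. Compound 4 `O=S(=O)(c1ccccc1)c1ccccc1-c1n[nH]c(=S)[nH]1` has not yet been measured. It differs from compound 2 by a group of 6 heavy atoms (2 carbon, 3 nitrogen, 1 sulfur; one five-membered aromatic ring with 3 hetero atoms) in place of a group of 6 heavy atoms (2 carbon, 3 nitrogen, 1 oxygen; one five-membered aromatic ring with 3 hetero atoms), on an aromatic carbon, the same kind of change as seen earlier. Compound 4 is expected to show a step of a number 12.7 percentage points higher from compound 2 to compound 4 (beyond the scatter), resting on the earlier step of a number 15.9 percentage points higher from compound 1 to compound 3 (beyond the scatter). Compound 4 is therefore estimated at 81%, between 68% and 93%.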

Compound 4, a percentage reported as inhibition, in the whole organism at one dose (the size of the read-out at that dose, not a potency): 64.9%
For compound 4 the middle estimate is 16.1 percentage points above the measured one, outside the stated range (below it).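

In this assay, replacing the 5-amino-1,3,4-oxadiazol-2-yl ring with the sulfur-containing ring gives a number 3.4 percentage points lower from compound 2 to compound 4 (within the scatter), so the gain seen on the core of compound 1 does not carry over to the core of compound 2. The two results for the same change do not agree: the same change on two cores in this assay, a number 15.9 percentage points higher (beyond the scatter) from compound 1 to compound 3 and a number 3.4 percentage points lower (within the scatter) from compound 2 to compound 4, 19.3 percentage points apart, beyond the scatter of two such steps In this series, then, the outcome of this ring swap cannot be assumed to transfer from one core to another, but two pairs cannot show why it differs or predict its outcome on a further core.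

The compounds shown leave open how the swap would behave if an ether oxygen or a methylene group replaced the sulfur link of compound 1. They also leave open whether a carboxylic acid on the outer benzene ring would alter the outcome.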